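The source may report more compounds than this note shows. Statements on the series, on what has been measured and on what is new or still open speak of the compounds shown alone.

Values in an ADME assay on Caco-2 cells (Homo sapiens) for permeability, in the apical to basolateral direction, at pH 7.4; a higher number here means that the compound crosses the layer faster, a lower number that the compound crosses the layer more slowly:

- Compound 1 `Cc1ccc2[nH]c(C(=O)N[C@H]3CN(S(=O)(=O)c4ccccc4)C[C@@H]3C(=O)N[C@H]3CCCN(C)C3)cc2c1`: 0.3 10^-6 cm/s
- Compound 2 `Cc1ccc2[nH]c(C(=O)N[C@H]3CN(S(=O)(=O)c4ccccc4)C[C@@H]3C(=O)N[C@@H]3CCCNC3)cc2c1`: 0.04 10^-6 cm/s

Among the measured compounds shown here, of these two compounds, compound 2 has the lower number, and its only neighbour is compound 1. The next compound to be tested is compound 3 `Cc1ccc2[nH]c(C(=O)N[C@H]3CN(S(=O)(=O)c4ccccc4)C[C@@H]3C(=O)N[C@H]3CCCNC3)cc2c1`, and (the two compounds have the same atoms and bonds and differ only in configuration as drawn: 1 of 3 stereo elements differ; a stereocentre at a saturated ring carbon is drawn R in compound 2 and S in compound 3). Such a pair is easy to overlook on paper, but it is a separate compound and need not behave identically in this assay. For the measured compounds named here, the only measured step, a 7.5-fold lower number from compound 1 to compound 2 (0.88 log units; beyond the scatter), replaces 1-methylpiperidin-3-yl with piperidin-3-yl. That is a different kind of change, so it gives neither a size nor a direction for this one. Going by the values given here, no measured pair isolates a change of configuration, so no shift beyond the scatter is expected. The estimate is a 1.3-fold higher number from compound 2 to compound 3 (0.10 log units; within the scatter). Compound 3 is expected at 0.05 10^-6 cm/s, within an estimated range of 0.02 10^-6 cm/s to 0.2 10^-6 cm/s.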

Compound 3, apparent permeability: 0.04 10^-6 cm/s
For compound 3 the middle estimate is 1.3-fold (0.10 log units) above the measured one; the range from low to high includes it.
By their numbers in this assay, from the lowest: compounds 2 and 3 (each within the scatter of the next); then compound 1.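

In this assay changing the stereocentre at the saturated ring carbon gives no change at the digits printed from compound 2 to compound 3 (within the scatter), so at this position the drawn configuration of the piperidin-3-yl group shows no effect beyond the scatter. The comparison tests that single feature: the fact that compounds 2 and 3 differ only in the configuration as drawn. Hydrogen in place of methyl on the ring nitrogen gives a 7.5-fold lower number from compound 1 to compound 3 (0.88 log units; beyond the scatter) and also a 7.5-fold lower number from compound 1 to compound 2 (0.88 log units; beyond the scatter), so the lower number appears with either configuration of the piperidin-3-yl group.

On these data alone, whether configuration is equally unimportant with a methyl on the ring nitrogen stays open, since the 1-methylpiperidin-3-yl group appears here in one configuration only. The compounds also leave open what a larger group on that nitrogen, such as ethyl or acetyl, would do to the number in this assay.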